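The source may report more compounds than this note shows. Statements on the series, on what has been measured and on what is new or still open speak of the compounds shown alone.

Compound 1 `CCc1nc2ccc(Br)cn2c1C(=O)NCCOc1ccc(Br)cc1` was examined in an ADME assay on cells (Hepatocyte, Homo sapiens) for metabolic stability (on this read-out lower numbers stand for a shorter-lived compound and higher numbers for a longer-lived compound), where compound 1 gave 0.263 h. A second member of the same core, compound 2 `CCc1nc2ccc(C)cn2c1C(=O)NCCOc1ccc(OC)cc1`, was run alongside it; in this assay compound 2 gave 0.325 h. Of these two numbers compound 1 holds the smaller, yet its distance to compound 2 falls within the scatter of repeated measurements, so the two cannot be told apart on this read-out.

Compound 3 `CCc1nc2ccc(Cl)cn2c1C(=O)NCCOc1ccc(Br)cc1` has not yet been measured. It differs from compound 1 in one place: chloro in place of bromo on an aromatic carbon. Among the measured compounds shown here, no step between measured compounds isolates this change; compound 1 and compound 2 differ in more than one place, so they say nothing direct about it. The step of a 1.1-fold higher number from compound 1 to compound 3 (0.03 log units; within the scatter) is expected to remain within the scatter, in no fixed direction, because compound 1 sits at 0.263 h and the change is confined to one halogen. For compound 3 in this assay the expected value is 0.28 h, within a range from 0.15 h to 0.55 h.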

Compound 3, half-life: 0.587 h
Estimate against measurement, compound 3: 2.1-fold (0.32 log units) below, and the stated range ends below it.
By their numbers in this assay, from the lowest: compounds 1, 2 and 3 (each within the scatter of the next, the first and the last beyond it).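

In this assay, among the compounds shown here, the step of a 2.2-fold higher number from compound 1 to compound 3 (0.35 log units; beyond the scatter) is the first change at this position that can be read on its own. It shows that exchanging one halogen for another on this aromatic carbon, with the rest of the structure shared, can move the half-life beyond the scatter, although the step is only modest. No measurement offered here accounts for the step, so it stands as an observation without an explanation.

The compounds shown compare only bromo and chloro through a single step at this carbon, so they leave open whether a fluoro or a nitrile there would continue the same direction. Going by these compounds, it also remains open whether the exchange would give a similar step if the remaining bromo were replaced by a trifluoromethyl.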